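Catechol ether benzamides: amide nitrogen substituent and PDE4A inhibition

A few compounds are considered here, and "the series" means these few. Any claim that something is new, unique, unknown or untested is made for them only; others in the source may bear on it.

Measured compounds:
compound 1 `COc1ccc(C(=O)Nc2ccccc2C)cc1OC1CCCC1` — 300 nM
compound 2 `COc1ccc(C(=O)Nc2c(F)cccc2F)cc1` — 37000 nM
compound 3 `COc1ccc(C(=O)Nc2ccccc2Cl)cc1OC(=O)c1ccccc1` — reported only as a limit, > 1000000 nM

All three share a methoxy-substituted benzamide core and were tested in an assay on isolated protein for inhibition of phosphodiesterase 4A (Sus scrofa); on this read-out higher numbers stand for weaker inhibition and lower numbers for stronger inhibition. Compound 1 gives 300 nM, the lowest of the two numbers in this assay; compound 2 gives 37000 nM, a much higher number, well beyond the scatter. For compound 3 the assay reports no number but a limit, > 1000000 nM; it is one of the values sitting at the limit of > 1000000 nM in this assay, at which 1 of the 3 values shown sits. No pair of these compounds differs in only one place, so no single step can be read from them.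

The unmeasured compound 4 `COc1ccc(C(=O)NN2C(Cl)=NC=CC2Cl)cc1OC1CCCC1` differs from compound 1 on the amide-type nitrogen: a group of 8 heavy atoms (4 carbon, 2 nitrogen, 2 chlorine; one six-membered non-aromatic ring with 2 hetero atoms) in place of a group of 7 heavy atoms (7 carbon; one six-membered aromatic ring of carbon only), on an amide-type nitrogen. The change removes the 2-methylphenyl group and brings in a chlorine-bearing non-aromatic ring attached through a second nitrogen. The shown compounds give no step of this kind, so the expectation rests on the general observation that compound 1 holds the lowest number while the other two amide nitrogen substituents give weaker inhibition. The step from compound 1 to compound 4 is expected to be a loss, a 10-fold higher number from compound 1 to compound 4 (1.00 log units; beyond the scatter), beyond the scatter. In this assay compound 4 is estimated at 3000 nM, with a range from 500 nM to 20000 nM.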

Compound 4, half-maximal inhibitory concentration: 400 nM
Compound 4: the middle estimate sits 7.5-fold (0.88 log units) above what was measured, and the stated range ends above it.
By their numbers in this assay, from the lowest: compounds 1 and 4 (each within the scatter of the next); then compound 2. At a limit, above all of these: compound 3.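

Among the compounds shown here, this is the first comparison that changes one place only: on the amide-type nitrogen, the 2-methylphenyl group gives way to a chlorine-bearing six-membered non-aromatic ring with 2 hetero atoms, and this assay shows a 1.3-fold higher number from compound 1 to compound 4 (0.12 log units; within the scatter). With the rest of the structure held, an aromatic ring of carbon only is therefore not required on this nitrogen for a number in this range, and a group with 2 hydrogen-bond acceptors can stand in place of one with none without separating the two values. No measured property in the data bears on this result.

Compounds 2 and 3 each differ from compound 1 in more than one place, so the part played by the amide nitrogen substituent in those two compounds remains unassigned. Also open, as far as these compounds go, is how far this nitrogen accepts other groups, such as a longer alkyl chain, a carboxylic acid or an amine, and whether the entering ring would give a similar number without its chlorine atoms.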